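The compounds below may be only part of what the source reports. "The series", "measured", "known", "first", "only" and "open" are said of these compounds alone.

Working notes on the series. Compound 1 `CCOc1cc(=O)n(CCCO)c2c1CC(CC=C(C)C)C(C)(C)C2` gives in a functional assay on PANC-1 cells (Homo sapiens) for inhibition, read by MTT assay, with a stated time of 24 h, tested at 10 uM (on this read-out higher numbers stand for more inhibition at the one concentration tested (going by the name of the read-out) and lower numbers for less inhibition), a value of 16.6%. Compound 2 `CC(C)=CCC1Cc2c(OCCCNC(=O)c3ccco3)cc(=O)n(CCCO)c2CC1(C)C` gives 4.3% in this assay, and compound 3 `COc1cccc(NC(=O)Oc2cc(=O)n(CCCO)c3c2CC(CC=C(C)C)C(C)(C)C3)c1` gives 0%. The step of a number 12.3 percentage points lower from compound 1 to compound 2 (beyond the scatter) and the step of a number 16.6 percentage points lower from compound 1 to compound 3 (beyond the scatter) are both beyond the scatter, whereas the step of a number 4.3 percentage points lower from compound 2 to compound 3 (within the scatter) is within it, so compound 3 stands with compound 2 at the low end of the three numbers, separated clearly only from compound 1.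

Compound 4 `CC(C)=CCC1Cc2c(OC(=O)Nc3ccc(F)c(F)c3)cc(=O)n(CCCO)c2CC1(C)C` differs from compound 3 in one place: 3,4-difluorophenyl in place of 3-methoxyphenyl on an amide-type nitrogen. Going by the values given here, none of the three measured steps touches the group on the amide-type nitrogen; the measured steps concern the oxygen on the aromatic ring and the saturated chain carbon, so no step bears directly on this change. Among the compounds with values here, with no measured precedent and compound 3 already at the floor of the read-out, no step beyond the scatter is expected: compound 4 is estimated at 3% (range 0% to 12%), a step of a number 3 percentage points higher from compound 3 to compound 4 (within the scatter) that is expected to remain within the scatter.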

Compound 4, a percentage reported as inhibition, at one concentration (the size of the read-out at that concentration, not a potency): 0%
Estimate against measurement, compound 4: 3 percentage points above; measured number inside the range.
By their numbers in this assay, from the lowest: compounds 3, 4 and 2 (each within the scatter of the next); then compound 1.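

In this assay the amide-type nitrogen now carries a measured change: 3,4-difluorophenyl in place of 3-methoxyphenyl gives no change at the digits printed from compound 3 to compound 4 (within the scatter), and any effect of this exchange stays hidden while both compounds sit at the bottom of the read-out. A second aryl carbamate gives the same picture on the oxygen on the aromatic ring, with a number 16.6 percentage points lower from compound 1 to compound 4 (beyond the scatter), matching the step to compound 3, while a number 4.3 percentage points lower from compound 2 to compound 4 (within the scatter) leaves compound 4 unseparated from compound 2. Nothing at hand accounts for these low numbers.

Open, as far as these compounds go, is whether a benzyl group or a pyridyl ring on the amide-type nitrogen would lift the number off the bottom of the read-out. Also open, from the compounds shown here alone, is whether a propyl or butyl chain on that oxygen, in place of ethyl, would raise the number of compound 1.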